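The source may report more compounds than this note shows. Statements on the series, on what has been measured and on what is new or still open speak of the compounds shown alone.

Compound 1 `CCN(c1ccc(C#N)c(Cl)c1)c1cc(-c2cncnc2)ccc1C` is the starting point in a functional assay on PC-3 cells (Homo sapiens) for antiproliferative activity, read by CCK-8 assay, with a stated time of 6 days; on this read-out lower numbers stand for stronger inhibition and higher numbers for weaker inhibition. In this assay compound 1 reads > 30000 nM, which is a limit of the assay and not a number. Compound 2 `Cc1noc(C)c1-c1cccc2c1CCCN2c1ccc(C#N)c(C(F)(F)F)c1` offers no comparison, as compound 2 has the entry "not determined" (no result reported). Compound 3 `CCN(c1ccc(C#N)c(Cl)c1)c1cc(-n2ccnc2)ccc1C` carries 1H-imidazol-1-yl in place of pyrimidin-5-yl on an aromatic carbon of the shared core (1H-imidazol-1-yl in place of pyrimidin-5-yl on an aromatic carbon). Among the measured compounds shown here, no measured step is available to size this change, so the expected move, a number no higher from compound 1 to compound 3 (the limit leaves the size open), is none beyond the scatter in this assay. Compound 3 is estimated at 30000 nM, with an expected range from 10000 nM to 60000 nM.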

Compound 3, half-maximal inhibitory concentration: > 30000 nM
Compound 3 ended at the assay's limit (the forecaster's own chance of this, stated with the estimate: 70%); the middle value sits exactly at the limit.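

No step can be read from compound 1 to compound 3 in this assay, because compound 1 and compound 3 both stand at a limit and not at a number: the limit of > 30000 nM in this assay, at which 2 of the 3 values shown sit. The compounds shown leave open how the pyrimidin-5-yl and 1H-imidazol-1-yl groups compare, and what change on the shared core would give a readable number.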